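The source may hold more compounds than are shown below. What is called first, only, known or untested is meant among the compounds shown, and "the series" means these compounds.

Working notes on the series.

Compound 2 `O=C(/C=C/c1ccccc1)Nc1cc2c(Nc3ccc(Cl)c(Cl)c3)ncnc2s1` gives 7600 nM in a functional assay on A549 cells (Homo sapiens) for antiproliferative activity, read by MTT assay, with a stated time of 48 h; a higher number here means a weaker inhibitor, a lower number a stronger inhibitor. Compound 1 `COc1ccc(/C=C/C(=O)Nc2cc3c(Nc4ccc(Cl)c(Cl)c4)ncnc3s2)cc1` differs from it only by methoxy in place of hydrogen on an aromatic carbon; in this assay compound 1 gives 3320 nM, and the step is a 2.3-fold lower number from compound 2 to compound 1 (0.36 log units; beyond the scatter). Compound 3 `O=C(/C=C/c1ccccc1)Nc1cc2ncnc(Nc3ccc(F)c(Cl)c3)c2s1` carries a different core; the difference between the two cores is not broken down here. In this assay compound 3 gives 6670 nM, a number within the scatter of compound 2. Compound 4 `COc1ccc(/C=C/C(=O)Nc2cc3ncnc(Nc4ccc(F)c(Cl)c4)c3s2)cc1` stands to compound 3 as compound 1 stands to compound 2: the change is methoxy in place of hydrogen on an aromatic carbon, with the same place description, so it is the same change. Among the measured compounds shown here, the single measured instance of it, a 2.3-fold lower number from compound 2 to compound 1 (0.36 log units; beyond the scatter), was modest but beyond the scatter. A step of similar size is expected here, a 2.3-fold lower number from compound 3 to compound 4 (0.36 log units; beyond the scatter), resting only on that one instance. Compound 4 is estimated at 2900 nM, with a likely range from 1500 nM to 6000 nM.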

Compound 4, half-maximal inhibitory concentration: 22700 nM
Estimate against measurement, compound 4: 7.8-fold (0.89 log units) below; the whole stated range lies below it.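

In this assay the change from phenyl to 4-methoxyphenyl gives a 3.4-fold higher number from compound 3 to compound 4 (0.53 log units; beyond the scatter), opposite in direction to the step on the other core, so in this series the step does not carry from one core to the other: the same change on two cores in this assay, a 2.3-fold lower number (0.36 log units; beyond the scatter) from compound 2 to compound 1 and a 3.4-fold higher number (0.53 log units; beyond the scatter) from compound 3 to compound 4, 7.8-fold (0.89 log units) apart, beyond the scatter of two such steps

Among the compounds shown here, this rests on only two pairs, one step on each core. The two pairs differ in more than one place, so the data do not show which structural difference goes with the reversal, nor why it occurs.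

Open, going by these compounds, is how a hydroxy group or an amine in the same place would behave on each core. Also open, on these data alone, is which direction the methoxy step would take on any further core.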